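Cyclohexyl for oxanyl at the amine: carrying the step over

The source may hold more compounds than are shown below. What is called first, only, known or untested is meant among the compounds shown, and "the series" means these compounds.

Compound 1 `C(=C/CN(C[C@H]1Cc2ccccc2CN1)[C@H]1CCCc2cccnc21)\CNC1CCOCC1` and compound 2 `CC1(C)CCC(NC/C=C/CN(C[C@H]2Cc3ccccc3CN2)[C@H]2CCCc3cccnc32)CC1` share one core; in a functional assay on cells for antagonist activity at C-X-C chemokine receptor type 4 (Homo sapiens), read by fluorescence and calcium flux, with stated times of 25 min and 90 s (on this read-out lower numbers stand for stronger inhibition and higher numbers for weaker inhibition), compound 1 gives 15.5 nM and compound 2 gives 64.6 nM. The change between them, (4,4-dimethylcyclohexyl in place of oxan-4-yl on an amine nitrogen), produced a 4.2-fold higher number from compound 1 to compound 2 (0.62 log units; beyond the scatter).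

Compound 3 `CC(C)(CCN(C[C@H]1Cc2ccccc2CN1)[C@H]1CCCc2cccnc21)CNC1CCOCC1` carries a different core; how it differs from the core of compound 1 is not broken down here. In this assay compound 3 gives 36.3 nM, a number beyond the scatter from that of compound 1 and within the scatter of that of compound 2.

Compound 4 `CC1(C)CCC(NCC(C)(C)CCN(C[C@H]2Cc3ccccc3CN2)[C@H]2CCCc3cccnc32)CC1` is not yet measured. It stands to compound 3 as compound 2 stands to compound 1: the change is 4,4-dimethylcyclohexyl in place of oxan-4-yl on an amine nitrogen, at the same place, and this is the second time the change appears in the series. With one measured instance, the expectation for compound 4 rests on that single step, and the step is expected to read about a 3.9-fold higher number from compound 3 to compound 4 (0.59 log units; beyond the scatter), close to the size seen from compound 1 to compound 2. On that basis compound 4 is estimated at 140 nM in this assay, with the likely range from 60 nM to 350 nM.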

Compound 4, half-maximal inhibitory concentration in the C-X-C chemokine receptor type 4 assay: 541 nM
The estimate for compound 4 lay 3.9-fold (0.59 log units) below the measured number, outside the stated range (above it).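

In the C-X-C chemokine receptor type 4 assay, 4,4-dimethylcyclohexyl in place of oxan-4-yl on an amine nitrogen gives a 15-fold higher number from compound 3 to compound 4 (1.17 log units; beyond the scatter), so the direction of the step carries over from one core to the other but its size does not: the same change on two cores in the C-X-C chemokine receptor type 4 assay, a 4.2-fold higher number (0.62 log units; beyond the scatter) from compound 1 to compound 2 and a 15-fold higher number (1.17 log units; beyond the scatter) from compound 3 to compound 4, 3.6-fold (0.55 log units) apart, beyond the scatter of two such steps. Going by these compounds alone, with only two cores compared, this does not show which feature of the core sets the size of the step. In a physicochemical assay for permeability, using PAMPA, with a stated time of 4 h, at pH 5.5, tested at 100 uM (a lower number here means that the compound crosses the layer more slowly, a higher number that the compound crosses the layer faster), compound 3 gives 57 nm/s and compound 4 gives 11 nm/s. Apparent permeability also shifts with the change on the core of compound 3, but nothing here ties that shift to the larger step in the C-X-C chemokine receptor type 4 assay: the measured apparent permeability of compound 3, 57 nm/s, and of compound 4, 11 nm/s, a 5.2-fold lower number (0.71 log units; beyond the scatter)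

From the compounds shown here alone, it remains open whether the larger step on the core of compound 3 follows from the cyclohexyl ring itself or from its methyl groups, which an unsubstituted cyclohexyl on an amine nitrogen on each core would separate. Going by these compounds, how a piperidin-4-yl group, with an amine in the ring, would read on either core is also open.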